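A Dichlorophenyl Swap Tested on a Second Core

This account rests on a few compounds, and the source may have more. Where it says the series, first, only, none or still open, it means among the compounds named here.

Compound 1 `CC(=O)N1N=C(c2cccc3ccccc23)CC1c1ccccc1[N+](=O)[O-]` and compound 2 `CC(=O)N1N=C(c2cccc3ccccc23)CC1c1cccc(Cl)c1Cl` share one core and differ in a single place. In a functional assay on IMR-32 cells (Homo sapiens) for cytotoxicity, read by sulforhodamine B assay, with a stated time of 48 h (a lower number here means a stronger inhibitor, a higher number a weaker inhibitor), compound 1 gives 3980 nM, while compound 2 gives 22100 nM. The change between them is 2,3-dichlorophenyl in place of 2-nitrophenyl on a saturated ring carbon, and it produced a 5.6-fold higher number from compound 1 to compound 2 (0.74 log units; beyond the scatter). Compound 3 `O=CCN1N=C(c2ccc3ccccc3c2)CC1c1ccccc1[N+](=O)[O-]` contains the same atoms as compound 1 joined differently; the difference between the two cores is not broken down here. In this assay compound 3 gives 3360 nM, a number within the scatter of compound 1 and well apart from compound 2. Compound 4 `O=CCN1N=C(c2ccc3ccccc3c2)CC1c1cccc(Cl)c1Cl` has not yet been measured. It differs from compound 3 by 2,3-dichlorophenyl in place of 2-nitrophenyl on a saturated ring carbon, the same kind of change as that from compound 1 to compound 2, though not the same: in compound 1 the saturated ring carbon is next to the ring atom that bears an acetyl group, whereas in compound 3 it is next to the ring atom that bears a formylmethyl group. A step of about a 5.4-fold higher number from compound 3 to compound 4 (0.73 log units; beyond the scatter) is expected because a 5.6-fold higher number from compound 1 to compound 2 (0.74 log units; beyond the scatter) was seen on the earlier core. Compound 4 is therefore estimated at 18000 nM, between 7000 nM and 50000 nM.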

Compound 4, half-maximal inhibitory concentration: 16900 nM
Compound 4: middle estimate off by 1.1-fold (0.03 log units), on the high side; low and high end bracket the measured number.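

Replacing 2-nitrophenyl with 2,3-dichlorophenyl on the core of compound 3 gives a 5.0-fold higher number from compound 3 to compound 4 (0.70 log units; beyond the scatter) in this assay, so the compound with the dichlorophenyl group is again the weaker one, and the two steps match in size: the same change on two cores in this assay, a 5.6-fold higher number (0.74 log units; beyond the scatter) from compound 1 to compound 2 and a 5.0-fold higher number (0.70 log units; beyond the scatter) from compound 3 to compound 4, 1.1-fold (0.04 log units) apart, within the scatter of two such steps

For these two cores, then, the effect of the change carried over from one to the other, even though the cores are not the same. Two pairs are a small base, however: they cannot show that the step would hold on a third core, and they do not explain why the number rises with this change.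

The compounds shown leave open how a phenyl ring carrying a single chlorine, or one carrying an amine or a carboxylic acid, would behave in this assay. They also leave open whether the step keeps its size when a longer chain stands where the acetyl or formylmethyl group sits.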